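Series notes: replacing the para substituent of compound 1

A few compounds are considered here, and "the series" means these few. Any claim that something is new, unique, unknown or untested is made for them only; others in the source may bear on it.

Compound 1 `CN(C)C(=O)c1cc2cnc(Nc3ccc(S(=O)(=O)NCCCCN=C=S)cc3)nc2n1C1CCCC1` stands highest of the three measured compounds in a functional assay on A549 cells (Homo sapiens) for inhibition, read by CCK-8 assay, with a stated time of 72 h, tested at 10 uM (a lower number here means a weaker effect, a higher number a stronger effect of the compound at the concentration tested), where compound 1 gives 101%. The nearest measured compound is compound 2 `CN(C)C(=O)c1cc2cnc(Nc3ccc(C(=O)NCCCCN=C=S)cc3F)nc2n1C1CCCC1`, which in this assay gives 24.4%, and the furthest is compound 3 `CN(C)C(=O)c1cc2cnc(Nc3ccc(C(=O)NCCCCCCN=C=S)cc3F)nc2n1C1CCCC1`, which gives 22.9%. Both gaps from compound 1 are beyond the scatter.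

The unmeasured compound 4 `CN(C)C(=O)c1cc2cnc(Nc3ccc(NC(=O)CCCN=C=S)cc3)nc2n1C1CCCC1` differs from compound 1 by a group of 9 heavy atoms (5 carbon, 2 nitrogen, 1 oxygen, 1 sulfur; no ring) in place of a group of 11 heavy atoms (5 carbon, 2 nitrogen, 2 oxygen, 2 sulfur; no ring), on an aromatic carbon, para to a large group. Among the compounds with values here, no measured pair shares exactly this change. Within the data shown here, the only single-point step, a number 1.5 percentage points lower from compound 2 to compound 3 (within the scatter), concerns the length of the chain carrying the isothiocyanate and is within the scatter, so chain length alone gives no guidance. Compound 2 and compound 3 differ from compound 1 in more than one place, so their low values can only be noted, not assigned to one change; still, both carry an amide-type nitrogen on the chain rather than the group of 11 heavy atoms of compound 1, and both sit far below compound 1.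

Compound 4 is therefore expected to fall well short of compound 1, with the step of a number 61 percentage points lower from compound 1 to compound 4 (beyond the scatter) estimated as a clear drop beyond the scatter. The value for compound 4 is estimated at 40%, within a range of 10% to 80%.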

Compound 4, a percentage reported as inhibition, at one concentration (the size of the read-out at that concentration, not a potency): 102%
Compound 4: middle estimate off by 62 percentage points, on the low side; measured number outside the range, above it.
By their numbers in this assay, from the lowest: compounds 3 and 2 (each within the scatter of the next); then compounds 1 and 4 (each within the scatter of the next).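

The step of a number 1 percentage points higher from compound 1 to compound 4 (within the scatter) in this assay shows that, on this aromatic carbon para to a large group, the group of 11 heavy atoms can give way to the group of 9 heavy atoms with no change beyond the scatter. Within the data shown here, the position therefore tolerates a change from 2 sulfur and 2 oxygen atoms to 1 of each, and from 4 hydrogen-bond acceptors to 3, at least at the single concentration tested; the earlier single-point step concerned only chain length, so this is the first reading at this position. No evidence here bears on why the two groups give matching read-outs.

As far as these compounds go, since the read-out is the size of the effect at one concentration, the effects of compound 1 and compound 4 at other concentrations remain unknown. From the compounds shown here alone, it also remains open how this position responds to a group without the isothiocyanate, such as a simple amine or a carboxylic acid, or to a longer chain on the group of 9 heavy atoms.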